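The source may hold more compounds than are shown below. What is called first, only, known or untested is meant among the compounds shown, and "the series" means these compounds.

Working notes on the series. In a functional assay on K562 cells (Homo sapiens) for inhibition, read by trypan blue exclusion, with a stated time of 72 h (a higher number here means a weaker inhibitor, a lower number a stronger inhibitor), compound 3 `Cc1ccc(S(=O)(=O)c2cc3cnc(Nc4cnc5c(c4)CC(=O)N5)nc3n(C)c2=O)cc1` gives 15000 nM, the middle of three numbers, with compound 1 `COc1ccc(Nc2ncc3cc(S(=O)(=O)c4ccc(C)cc4)c(=O)n(C)c3n2)cc1` higher at 75000 nM and compound 2 `Cn1c(=O)c(S(=O)(=O)c2ccc(OC(=O)CCCCC3SCC4NC(=O)NC43)cc2)cc2cnc(Nc3ccc4[nH]ccc4c3)nc21` lower at 600 nM.

Compound 4 `Cc1ccc(S(=O)(=O)c2cc3cnc(Nc4ccc5cc[nH]c5c4)nc3n(C)c2=O)cc1` keeps the rest of compound 3 and changes one group, on a nitrogen on an aromatic ring: a group of 9 heavy atoms (8 carbon, 1 nitrogen; one five-membered aromatic ring with 1 hetero atom, one six-membered aromatic ring of carbon only) in place of a group of 10 heavy atoms (7 carbon, 2 nitrogen, 1 oxygen; one five-membered non-aromatic ring with 1 hetero atom, one six-membered aromatic ring with 1 hetero atom), on a nitrogen on an aromatic ring. The entering group is 1H-indol-6-yl.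

Within the data shown here, one measured step bears directly on this place: a 5.0-fold lower number from compound 1 to compound 3 (0.70 log units; beyond the scatter). It was modest but beyond the scatter, and it shows that this assay responds to exchanges on this nitrogen. Among the measured compounds shown here, no measured pair isolates the present exchange. Compound 2, at 600 nM, also has a five-membered aromatic ring with 1 hetero atom and a six-membered aromatic ring of carbon only on this nitrogen, but it differs from compound 3 elsewhere too, so it gives only weak support.

A step of similar size to the measured one is therefore expected, towards a lower number. The expected change is a 5.0-fold lower number from compound 3 to compound 4 (0.70 log units; beyond the scatter), with wide uncertainty. The estimated value for compound 4 is 3000 nM, within an expected range of 600 nM to 15000 nM.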

Compound 4, half-maximal inhibitory concentration: 15000 nM
Compound 4: the middle estimate sits 5.0-fold (0.70 log units) below what was measured; the measured number falls inside the stated range.
By their numbers in this assay, from the lowest: compound 2; then compounds 3 and 4 (each within the scatter of the next); then compound 1.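

In this assay, replacing the group of compound 3 with 1H-indol-6-yl gives no change at the digits printed from compound 3 to compound 4 (within the scatter), so on this nitrogen the two groups cannot be told apart, although the entering group has no hydrogen-bond acceptors, no double bond outside aromatic rings and a six-membered aromatic ring of carbon only. Measured against 4-methoxyphenyl, 1H-indol-6-yl gives a 5.0-fold lower number from compound 1 to compound 4 (0.70 log units; beyond the scatter), the same size as a 5.0-fold lower number from compound 1 to compound 3 (0.70 log units; beyond the scatter), so the two groups with a five-membered ring share one modest step in this assay, and the response at this place does not track the counted differences between them. Nothing measured here accounts for this agreement between compound 3 and compound 4.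

Still open, on these data alone, is how an amine or a carboxylic acid carried on the aromatic group at this nitrogen would read in this assay. Compound 2 differs from each of the other compounds in more than one place, so its value cannot be assigned to any single exchange.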